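A few compounds are considered here, and "the series" means these few. Any claim that something is new, unique, unknown or untested is made for them only; others in the source may bear on it.

Measured compounds:
- compound 1 `O=C1c2c(O)cc(O)cc2O[C@H](c2cccc(O)c2)[C@H]1O`: > 100000 nM, a limit
- compound 2 `O=C1c2c(O)cc(O)cc2O[C@H](c2cccc(O)c2O)[C@H]1O`: 12500 nM
- compound 3 `O=C1c2c(O)cc(O)cc2O[C@H](c2ccccc2O)[C@H]1O`: > 100000 nM, a limit

In a physicochemical assay, read by spectrophotometry, with a stated time of 30 min (a lower number here means that less compound is needed, a higher number that more compound is needed for the effect), compound 1 gives > 100000 nM, which is a limit of the assay and not a number. Compound 1 therefore has no exact place on the scale, and it sits at the limit of > 100000 nM in this assay, at which 2 of the 3 values shown sit. Compound 4 `O=C1c2c(O)cc(O)cc2O[C@@H](c2cccc(O)c2)[C@@H]1O` is the mirror image of compound 1: the two compounds have the same atoms and bonds and differ only in configuration as drawn: 2 of 2 stereo elements differ (all stereocentres are inverted: mirror images); a stereocentre at a saturated ring carbon is drawn R in compound 1 and S in compound 4; a stereocentre at a saturated ring carbon is drawn R in compound 1 and S in compound 4.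

The measured steps bear on this change only indirectly. Adding hydroxy in place of hydrogen on an aromatic carbon gave an at least 8.0-fold lower number from compound 1 to compound 2 (0.90 log units; beyond the scatter). Removing it again gave an at least 8.0-fold higher number from compound 2 to compound 3 (0.90 log units; beyond the scatter). The remaining comparison, with 2-hydroxyphenyl in place of 3-hydroxyphenyl, is a step that the two limits leave unreadable from compound 1 to compound 3. All three steps alter the atoms or their connections, and none tests configuration alone, so they offer no size to carry over. Compound 4 has the same atoms and bonds as compound 1, and no step beyond the scatter is expected in this assay, in either direction.

The expectation rests on compound 1, whose > 100000 nM is a limit. The expected change is a step that the limit leaves unreadable from compound 1 to compound 4. A report of only a limit is the likeliest outcome. The estimate for compound 4 is 150000 nM, within an expected range of 70000 nM to 300000 nM.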

Compound 4, half-maximal effective concentration: > 100000 nM
Compound 4: no number, only a limit; the forecaster's own chance of this, stated with the estimate: 85%; the middle value is on the limit's open side.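

In this assay compound 4 gives > 100000 nM, which is a limit of the assay and not a number. For the compounds shown here, compound 1 also stands at a limit, so no step between compound 1 and compound 4 can be read: the limit of > 100000 nM in this assay, at which 3 of the 4 values shown sit. The compounds shown leave open whether inverting both stereocentres changes the result in this assay at all.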